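Allyl on the ring amine of compound 1

The compounds below may be only part of what the source reports. "The series", "measured", "known", "first", "only" and "open" are said of these compounds alone.

Measured so far in an assay on isolated protein for binding affinity to histone acetyltransferase KAT2B (Homo sapiens), read by isothermal titration calorimetry; a lower number here means tighter binding, a higher number weaker binding:
compound 1 `CN1C[C@H](Nc2nc3cc[nH]c3c(=O)n2C)C[C@H](c2ccccc2)C1` gives 152 nM
compound 2 `C=CCn1c(N[C@@H]2C[C@H](c3ccccc3)CN(C)C2)nc2cc[nH]c2c1=O` gives 676 nM
compound 3 `CC=CCn1c(N[C@@H]2C[C@H](c3ccccc3)CN(C)C2)nc2cc[nH]c2c1=O` gives 3040 nM

Compound 1 has the lowest number of the three. Its nearest neighbour is compound 2, with a 4.4-fold higher number from compound 1 to compound 2 (0.65 log units; beyond the scatter); the furthest is compound 3, with a 20-fold higher number from compound 1 to compound 3 (1.30 log units; beyond the scatter). Between those two there is a 4.5-fold higher number from compound 2 to compound 3 (0.65 log units; beyond the scatter).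

Compound 4 `C=CCN1C[C@H](Nc2nc3cc[nH]c3c(=O)n2C)C[C@H](c2ccccc2)C1` differs from compound 1 in one place: vinyl in place of hydrogen on a saturated chain carbon bound to an amine nitrogen in a ring. Among the measured compounds shown here, no measured step touches this place. The steps that exist all concern the saturated chain carbon bound to an aromatic nitrogen, on the other side of the shared core, where a vinyl group entering cost a modest amount and a larger group cost more. The same group entering here may be tolerated differently, so the expectation is a small weakening at most, possibly nothing beyond the scatter.

For compound 4 the estimate in this assay is 300 nM, with a range from 90 nM to 1000 nM, which would be a step of a 2.0-fold higher number from compound 1 to compound 4 (0.30 log units; within the scatter) from compound 1 and is only an expectation.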

Compound 4, dissociation constant: 233 nM
For compound 4 the middle estimate is 1.3-fold (0.11 log units) above the measured one; low and high end bracket the measured number.
By their numbers in this assay, from the lowest: compounds 1 and 4 (each within the scatter of the next); then compound 2; then compound 3.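

In this assay, allyl replaces methyl on the ring amine with a 1.5-fold higher number from compound 1 to compound 4 (0.19 log units; within the scatter) at this place, so the two compounds cannot be told apart here. The same vinyl entering on the saturated chain carbon bound to an aromatic nitrogen gave a 4.4-fold higher number from compound 1 to compound 2 (0.65 log units; beyond the scatter) as its step, so the cost seen at that place does not carry over to the carbon bound to the amine nitrogen in a ring. No measurement at hand explains why the two places differ.

With only this one group shown on the ring amine, it remains open how far the place accepts change, for instance a longer chain or a benzyl group. A chain ending in a carboxylic acid or an amine could also give a different answer here.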